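Lengthening the Chain Beneath a Cyanoguanidine Swap

This account rests on a few compounds, and the source may have more. Where it says the series, first, only, none or still open, it means among the compounds named here.

Of the compounds shown here, three sharing one core have been tested in a functional assay on the whole organism with Rattus norvegicus as the target, at a dose of 100 mg/kg; on this read-out higher numbers stand for more inhibition at the one dose given (going by the name of the read-out) and lower numbers for less inhibition. Compound 1 `CN(C)/C(=N/CCCCn1nc(-c2ccccc2)ccc1=O)NC#N` and compound 2 `CC/N=C(/NC#N)NCCCCn1nc(-c2ccccc2)ccc1=O` carry a chain of the same length between the core and the cyanoguanidine end, while compound 3 `CC/N=C(/NC#N)NCCCCCn1nc(-c2ccccc2)ccc1=O` carries a chain one bond longer. In this assay compound 1 gives 80.7%, compound 2 gives 58.8%, and compound 3 gives 48.2%, the lowest of the three.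

Compound 2 and compound 1 differ in one place: a group of 8 heavy atoms (4 carbon, 4 nitrogen; no ring) in place of a group of 8 heavy atoms (4 carbon, 4 nitrogen; no ring), on a saturated chain carbon, four bonds along the chain from an aromatic nitrogen. This swap brings a step of a number 21.9 percentage points higher from compound 2 to compound 1 (beyond the scatter). Compound 3 and compound 2 differ in how far the end group sits from the core, and the difference between the two cores is not broken down here.

Compound 4 `CN(C)/C(=N/CCCCCn1nc(-c2ccccc2)ccc1=O)NC#N` has not yet been measured. It is made from compound 3 by the same kind of change that turned compound 2 into compound 1: a group of 8 heavy atoms (4 carbon, 4 nitrogen; no ring) in place of a group of 8 heavy atoms (4 carbon, 4 nitrogen; no ring), on a saturated chain carbon, five bonds along the chain from an aromatic nitrogen. The two changes are the same kind but not the same. In compound 3 and compound 4 the group sits five bonds along the chain from the aromatic nitrogen rather than four. Compound 4 is expected to rise from compound 3 by about a number 19.8 percentage points higher from compound 3 to compound 4 (beyond the scatter), resting on the step seen between compound 2 and compound 1, a number 21.9 percentage points higher from compound 2 to compound 1 (beyond the scatter), with some allowance for the longer chain. Compound 4 is therefore estimated at 68%, likely between 54% and 82%.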

Compound 4, a percentage reported as inhibition, in the whole organism at one dose (the size of the read-out at that dose, not a potency): 63.9%
The estimate for compound 4 lay 4.1 percentage points above the measured number; low and high end bracket the measured number.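

Moved onto the longer chain, the swap of the end group still raises the number in this assay, bringing a number 15.7 percentage points higher from compound 3 to compound 4 (beyond the scatter), so the change carries over from one core to the other in the same direction and at a similar size. Set side by side, the two steps cannot be told apart, and nothing here shows that the longer chain weakens the effect of the swap: the same change on two cores in this assay, a number 21.9 percentage points higher (beyond the scatter) from compound 2 to compound 1 and a number 15.7 percentage points higher (beyond the scatter) from compound 3 to compound 4, 6.2 percentage points apart, within the scatter of two such steps This rests on only two pairs of compounds, each read at a single dose, so it shows neither how potent the compounds are nor why the swap raises the number, and it does not promise the same step on any other core.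

What happens to the swap on a chain longer than those shown remains open, as does whether the step would keep its size at other doses. On these data alone, it is also open how an amine or a carboxylic acid at the end of the chain, in place of the groups seen here, would read in this assay.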